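Chloro to methyl across two cores: working notes

The source may report more compounds than this note shows. Statements on the series, on what has been measured and on what is new or still open speak of the compounds shown alone.

Compound 1 `O=C(c1ccc(Cl)cc1)N1CC(c2nc(-c3cccc(F)c3)no2)C1` and compound 2 `Cc1ccc(C(=O)N2CC(c3nc(-c4cccc(F)c4)no3)C2)cc1` share one core. In an assay on HEK293 cells for negative allosteric modulation of metabotropic glutamate receptor 5 (Homo sapiens), read by FLIPR (on this read-out lower numbers stand for stronger inhibition and higher numbers for weaker inhibition), compound 1 reports only a limit, > 10000 nM. Compound 2 likewise reports only a limit in this assay, > 10000 nM. The change between them is methyl in place of chloro on an aromatic carbon; the step that the two limits leave unreadable from compound 1 to compound 2 cannot be sized because of the limit of > 10000 nM in this assay, at which 2 of the 3 values shown sit. Compound 3 `O=S(=O)(c1ccc(Cl)cc1)N1CC(c2nc(-c3cccc(Cl)c3)no2)C1` sits on a second core; the difference between the two cores is not broken down here. In this assay, going by the values given here, compound 3 gives 170 nM, the only number in the set. Compound 4 `Cc1cccc(-c2noc(C3CN(S(=O)(=O)c4ccc(Cl)cc4)C3)n2)c1` is not yet measured and differs from compound 3 by methyl in place of chloro on an aromatic carbon. This is the same kind of change as in the first pair, though there the group sits para to a large group and here meta to a large group. Since the first pair yields no readable size, the expectation rests on compound 3 alone at 170 nM, and a small step of a 1.5-fold higher number from compound 3 to compound 4 (0.17 log units; within the scatter) is expected. The estimate for compound 4 in this assay is 250 nM, between 80 nM and 800 nM.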

Compound 4, half-maximal inhibitory concentration: 1100 nM
Compound 4: the middle estimate sits 4.4-fold (0.64 log units) below what was measured; the whole stated range lies below it.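

In this assay, methyl in place of chloro on the second core gives a 6.5-fold higher number from compound 3 to compound 4 (0.81 log units; beyond the scatter), so 3-chlorophenyl to 3-methylphenyl is not a neutral change on that core. The same change on the first core cannot be read, because compound 1 and compound 2 both stand at a limit and not at a number: the limit of > 10000 nM in this assay, at which 2 of the 4 values shown sit. Whether the step carries from one core to the other therefore stays unshown, and the two pairs also make the change at different places.

Open, going by these compounds, is how an amine or a nitrile in place of the chloro of compound 3 would read on the second core. Also open, on these data alone, is whether a chloro to methyl change on the other aromatic ring of that core gives a step of similar size.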